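Working notes on a fluoro-to-chloro step

The compounds below may be only part of what the source reports. "The series", "measured", "known", "first", "only" and "open" are said of these compounds alone.

Measured so far in an ADME assay on GES1 cells (Homo sapiens) for cytotoxicity, read by MTT assay, with a stated time of 24 h; a lower number here means that less compound is tolerated, a higher number that more compound is tolerated:
- compound 1 `Cc1cccc(-n2cc(-c3cccc(NS(=O)(=O)c4c[nH]c(=O)[nH]c4=O)c3)nn2)c1`, 18500 nM
- compound 2 `Cc1ccc(-n2cc(-c3cccc(NS(=O)(=O)c4c[nH]c(=O)[nH]c4=O)c3)nn2)cc1`, 15800 nM
- compound 3 `O=c1[nH]cc(S(=O)(=O)Nc2cccc(-c3cn(-c4ccccc4F)nn3)c2)c(=O)[nH]1`, reported as "not toxic" (no number reported) with no number given

Compound 3 therefore stands apart from the other two: compound 1 and compound 2 each have a number in this assay, whereas compound 3 has none and is described only as tolerated. Among the compounds with values here, the one step that can be sized, a 1.2-fold lower number from compound 1 to compound 2 (0.07 log units; within the scatter), involves a methylphenyl on the aromatic nitrogen and does not touch the position changed here; it shows that moving a small group on that ring leaves this assay unchanged within the scatter.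

Compound 4 `O=c1[nH]cc(S(=O)(=O)Nc2cccc(-c3cn(-c4ccccc4Cl)nn3)c2)c(=O)[nH]1` differs from compound 3 by chloro in place of fluoro on an aromatic carbon. Within the data shown here, no measured step exchanges one halogen for another, so no direct precedent exists. Given that compound 3 reports "not toxic" (no number reported) and that the nearest comparable change, a 1.2-fold lower number from compound 1 to compound 2 (0.07 log units; within the scatter), lay within the scatter, no shift beyond the scatter is expected in this assay.

The estimate for compound 4 is 20000 nM, with an expected range from 8000 nM to 60000 nM, and a real chance that again only a qualitative outcome is reported.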

Compound 4, half-maximal cytotoxic concentration: 14000 nM
Compound 4: middle estimate off by 1.4-fold (0.15 log units), on the high side, and the stated range covers the measured number.
By their numbers in this assay, from the lowest: compounds 4, 2 and 1 (each within the scatter of the next).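

In this assay the 2-chlorophenyl group on the aromatic nitrogen carries a number, with compound 4 at 14000 nM, whereas compound 3, with 2-fluorophenyl, is described only in words, so the step from fluoro to chloro cannot be read as a size. Set against the two methylphenyl compounds, the readable steps are a 1.1-fold lower number from compound 2 to compound 4 (0.05 log units; within the scatter) and a 1.3-fold lower number from compound 1 to compound 4 (0.12 log units; within the scatter), so 2-chlorophenyl, 4-methylphenyl and 3-methylphenyl cannot be told apart in this assay, something the earlier compounds showed only for the two methylphenyl groups. Nothing at hand bears on why these readings stay together.

Still open, on these data alone, is whether compound 3 would give a number close to these three, which leaves the effect of the halogen exchange itself without a size. Also open is whether an amine or a carboxylic acid in place of chloro on this ring would keep the reading in this assay with these compounds, as the groups shown on the ring are limited to methyl, fluoro and chloro.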